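A few compounds are considered here, and "the series" means these few. Any claim that something is new, unique, unknown or untested is made for them only; others in the source may bear on it.

Measured in a functional assay on SK-OV-3 cells (Homo sapiens) for cytotoxicity; a higher number here means that more compound is needed for the effect, a lower number that less compound is needed:
- compound 1 `C#C/C=C\CCCCCCCCCCCCCC/C=C/CCCC/C=C/CCCCC#C[C@@H](O)C#CCCCCCC/C=C/[C@H](O)C#C`: 0.6 ug/mL
- compound 2 `C#C/C=C\CCCCCCCCCCCCCC/C=C/CCCC/C=C/CC/C=C/C#C[C@@H](O)C#CCCCCCC/C=C/[C@H](O)C#C`: 0.5 ug/mL

For the measured compounds named here, only these two compounds have numbers so far, and they lie within the scatter of each other. Compound 1 therefore cannot be separated from compound 2 in this assay, and the pair marks a single level for the series.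

The next compound is compound 3 `C#C/C=C\CCCCCCCCCCCCCC/C=C/CCCC/C=C/CCCCC#C[C@@H](O)C#CCCCCCCCC[C@H](O)C#C`, not yet measured in this assay. The change from compound 1 is a group of 6 heavy atoms (5 carbon, 1 oxygen; no ring) in place of a group of 6 heavy atoms (5 carbon, 1 oxygen; no ring), on a saturated chain carbon, six bonds along the chain from a triple-bonded carbon. A group of the same heavy-atom count and the same atom types takes the place of the old one, on a saturated chain carbon, six bonds along the chain from a triple-bonded carbon. The entering group carries no double bond.

Going by the values given here, no measured pair shows this change, so there is no direct step to carry over. The expectation therefore starts from the level of compound 1 at 0.6 ug/mL, and no shift beyond the scatter is expected, with any small drift more likely towards a higher number. The expected size of the change is a 1.2-fold higher number from compound 1 to compound 3 (0.07 log units; within the scatter). For compound 3 the estimated value is 0.7 ug/mL, with an expected range of 0.25 ug/mL to 2 ug/mL.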

Compound 3, concentration for half-maximal effect: 2.2 ug/mL
Compound 3: the middle estimate sits 3.1-fold (0.50 log units) below what was measured; measured number outside the range, above it.
By their numbers in this assay, from the lowest: compounds 2 and 1 (each within the scatter of the next); then compound 3.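

In this assay, the first replacement at this place, on a saturated chain carbon, six bonds along the chain from a triple-bonded carbon, gives a 3.7-fold higher number from compound 1 to compound 3 (0.56 log units; beyond the scatter), so this part of the chain is not indifferent to change even though the swap is a close one. The leaving and entering groups match in heavy atoms, hydrogen-bond donors and acceptors, defined stereocentres and triple bonds, and the one counted difference is the double bond, present in the group of compound 1 and absent from the group of compound 3; loss of that double bond therefore goes with the higher number in this single pair. Nothing at hand accounts for the size of the step or says why it arises.

One pair cannot show whether the double bond itself matters or whether the same change would carry over to the core of compound 2. Also open, as far as these compounds go, is how this place responds to other groups, such as an amine in place of the hydroxyl or a longer chain at the same carbon.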